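Replacing the thiophene on a shared core

The source may hold more compounds than are shown below. What is called first, only, known or untested is meant among the compounds shown, and "the series" means these compounds.

In a functional assay on cells (Cancer cell lines, Homo sapiens) for inhibition (on this read-out lower numbers stand for stronger inhibition of growth and higher numbers for weaker inhibition of growth), compound 1 `N=C(N)N/N=C/c1c(-c2cc(Cl)sc2Cl)nc2n1CCS2` gives 11200 nM, compound 2 `N=C(N)N/N=C/c1c(-c2ccsc2)nc2n1CCS2` gives 28800 nM, and compound 3 `Cc1cc(-c2nc3n(c2/C=N/NC(=N)N)CCS3)c(C)s1` gives 17000 nM. Only one step among these three clears the scatter, a modest one: a 2.6-fold higher number from compound 1 to compound 2 (0.41 log units; beyond the scatter). Compound 3 cannot be separated from either of the other two, with a 1.5-fold higher number from compound 1 to compound 3 (0.18 log units; within the scatter) and a 1.7-fold lower number from compound 2 to compound 3 (0.23 log units; within the scatter).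

Compound 4 `N=C(N)N/N=C/c1c(-c2cccs2)nc2n1CCS2` is still unmeasured. Its structure departs from that of compound 3 by this change: thiophen-2-yl in place of 2,5-dimethylthiophen-3-yl on an aromatic carbon. Among the measured compounds shown here, no measured compound carries thiophen-2-yl, so no step shows this exchange directly. The closest guide is compound 2, which has thiophen-3-yl and gives 28800 nM, and the step that links it to the dimethyl compound is small: a 1.7-fold lower number from compound 2 to compound 3 (0.23 log units; within the scatter). A small move towards a higher number in this assay is therefore expected, probably not far beyond the scatter. The expected step is a 1.5-fold higher number from compound 3 to compound 4 (0.18 log units; within the scatter). Compound 4 is estimated at 26000 nM, with an expected range from 12000 nM to 50000 nM.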

Compound 4, concentration for 50% growth inhibition: 28800 nM
Beside the measured number, compound 4's estimate is 1.1-fold (0.04 log units) below it; the range from low to high includes it.
By their numbers in this assay, from the lowest: compounds 1, 3, 2 and 4 (each within the scatter of the next, the first and the last beyond it).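

Exchanging thiophen-3-yl for thiophen-2-yl on this aromatic carbon gives no readable difference in this assay (no change at the digits printed from compound 2 to compound 4 (within the scatter)), so among the unsubstituted thiophenes shown, the point of attachment does not separate the compounds. Compound 4 also cannot be separated from the 2,5-dimethylthiophen-3-yl compound (a 1.7-fold higher number from compound 3 to compound 4 (0.23 log units; within the scatter)), whereas the step from the 2,5-dichlorothiophen-3-yl compound clears the scatter (a 2.6-fold higher number from compound 1 to compound 4 (0.41 log units; beyond the scatter)) and matches the modest step already seen with thiophen-3-yl (a 2.6-fold higher number from compound 1 to compound 2 (0.41 log units; beyond the scatter)). No measured evidence is available to explain these steps.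

On these data alone, because compound 1 and compound 3 remain within the scatter of each other, it stays open whether the two chlorines do anything that the two methyl groups do not. Also open, as far as these compounds go, is how a phenyl ring, or a thiophene carrying an amine or a carboxylic acid, would read at this position.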